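This account rests on a few compounds, and the source may have more. Where it says the series, first, only, none or still open, it means among the compounds named here.

Of the compounds shown here, three built on one shared core have been tested in a functional assay on HGC-27 cells (Homo sapiens) for inhibition, read by MTT assay, with a stated time of 72 h; on this read-out lower numbers stand for stronger inhibition and higher numbers for weaker inhibition. Compound 1 `Cc1cc(N2CC[C@@H](C)[C@@H](N(C)c3ncnc4[nH]ccc34)C2)n2nc(SCc3cc(Cl)ccc3Cl)nc2n1` gives 19200 nM. Compound 2 `C=CCSc1nc2nc(C)cc(N3CC[C@@H](C)[C@@H](N(C)c4ncnc5[nH]ccc45)C3)n2n1` gives 35200 nM, the highest of the three numbers. Compound 3 `Cc1cc(N2CC[C@@H](C)[C@@H](N(C)c3ncnc4[nH]ccc34)C2)n2nc(SCc3ccccc3)nc2n1` gives 13900 nM. The step of a 1.8-fold higher number from compound 1 to compound 2 (0.26 log units; within the scatter), so those two compounds cannot be told apart. The step of a 2.5-fold lower number from compound 2 to compound 3 (0.40 log units; beyond the scatter), a modest difference in favour of compound 3.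

Compound 4 `C#CSc1nc2nc(C)cc(N3CC[C@@H](C)[C@@H](N(C)c4ncnc5[nH]ccc45)C3)n2n1` has not yet been measured. It differs from compound 2 in one place: ethynyl in place of allyl on a sulfur. Both of the steps that change the group on this sulfur bear on it, and both were small: the step from compound 1 to compound 2 stayed inside the usual spread, and the step from compound 2 to compound 3 was only modest. Nothing measured here swaps one short chain for another, so the expected change in this assay is small. For compound 4 the estimated value is 38000 nM, with a range from 15000 nM to 95000 nM, which is expected to mean a step of a 1.1-fold higher number from compound 2 to compound 4 (0.03 log units; within the scatter).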

Compound 4, half-maximal inhibitory concentration: 35100 nM
Beside the measured number, compound 4's estimate is 1.1-fold (0.03 log units) above it; measured number inside the range.
By their numbers in this assay, from the lowest: compounds 3, 1, 4 and 2 (each within the scatter of the next, the first and the last beyond it).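

In this assay, ethynyl in place of allyl on this sulfur gives a 1.0-fold lower number from compound 2 to compound 4 (0.00 log units; within the scatter), so a triple bond in place of a double bond leaves the two short chains impossible to tell apart. Ethynyl in place of 2,5-dichlorobenzyl likewise stays inside the scatter, with a 1.8-fold higher number from compound 1 to compound 4 (0.26 log units; within the scatter), while ethynyl in place of benzyl gives a 2.5-fold higher number from compound 3 to compound 4 (0.40 log units; beyond the scatter), a modest difference in favour of the benzyl compound. No supporting data are available to explain these results.

The compounds shown leave open what an amine or a carboxylic acid on the chain attached to this sulfur, or a longer chain, would do to the number. They also leave open whether any group here could give a difference larger than the modest one seen with benzyl.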